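The source may report more compounds than this note shows. Statements on the series, on what has been measured and on what is new or still open speak of the compounds shown alone.

Compound 1 `CC(=O)N1CCc2cc(-c3cccc4c3CCCC4)cc(N3CCCC3=O)c21`: 271000 nM
Compound 2 `CC(=O)N1CCc2cc(-c3cccc4c3CCCC4)cc(N3CCCCC3=O)c21`: 259000 nM
Compound 3 `O=C1CCCN1c1cccc(C(=O)N(c2ncccc2Cl)[C@@H]2CCCNC2)c1`: 67000 nM

These three compounds have been measured in a physicochemical assay for solubility, at pH 7.4; on this read-out lower numbers stand for lower solubility and higher numbers for higher solubility. Compound 1 and compound 2 share one core and differ in a single place: 2-oxopiperidin-1-yl in place of 2-oxopyrrolidin-1-yl on an aromatic carbon. That change gave a 1.0-fold lower number from compound 1 to compound 2 (0.02 log units; within the scatter). Compound 3 is built on another core; the difference between the two cores is not broken down here, and in this assay compound 3 sits lowest of the three, beyond the scatter from both others.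

Compound 4 `O=C1CCCCN1c1cccc(C(=O)N(c2ncccc2Cl)[C@@H]2CCCNC2)c1` has not yet been measured in this assay. It stands to compound 3 as compound 2 stands to compound 1: 2-oxopiperidin-1-yl in place of 2-oxopyrrolidin-1-yl on an aromatic carbon. The surroundings of the place are not identical, though. In compound 1 the aromatic carbon is part of a fused or bridged system of two rings, ortho to a fused ring and meta to a fused ring, while in compound 3 it is not; both are meta to a large group. So this is the same kind of change, not the same change.

Because the earlier change gave a 1.0-fold lower number from compound 1 to compound 2 (0.02 log units; within the scatter) and stayed within the scatter, a similarly small step is expected here, a 1.1-fold lower number from compound 3 to compound 4 (0.03 log units; within the scatter). Compound 4 is therefore estimated at 62000 nM, with a likely range from 30000 nM to 130000 nM.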

Compound 4, solubility: > 973000 nM
Compound 4 gave a limit, no number (the forecaster's own chance of this, stated with the estimate: 3%); middle value at least 15-fold (1.19 log units) away from the limit.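

In this assay, compound 4 gives > 973000 nM, which is a limit of the assay and not a number. The same exchange of 2-oxopyrrolidin-1-yl for 2-oxopiperidin-1-yl gave a 1.0-fold lower number from compound 1 to compound 2 (0.02 log units; within the scatter), yet on the other core it gave an at least 14-fold higher number from compound 3 to compound 4 (1.16 log units; beyond the scatter), so the small effect seen on the first core did not carry over to the second. This does not show why the two cores respond differently, and it gives no exact size for the second step, since the value of compound 4 is a limit: the limit of > 973000 nM in this assay, at which 1 of the 4 values shown sits.

Going by these compounds, each core is represented here by a single pair, so it remains open whether the exchange would behave like either of these steps on a third core. On these data alone, it also remains open what a larger ring such as 2-oxoazepan-1-yl, or an open-chain acetamide, would do at the same place on the core of compound 3.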